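The source may report more compounds than this note shows. Statements on the series, on what has been measured and on what is new or still open speak of the compounds shown alone.

Measured so far in a functional assay on MOLT-4 cells (Homo sapiens) for cytotoxicity, read by sulforhodamine B assay, with a stated time of 48 h; a lower number here means a stronger inhibitor of growth, a higher number a weaker inhibitor of growth:
compound 1 `ClCc1cccc(Cn2cnc3c(Cl)ncnc32)c1` gives 37200 nM.
compound 2 `ClCc1cccc(Cn2cnc3c(Cl)nc(Cl)nc32)c1` gives > 100000 nM, which is a limit of this assay and not a number.

Compound 2 therefore stands at the limit (the limit of > 100000 nM in this assay, at which 1 of the 2 values shown sits), so only a range is known for it, and any step that starts from compound 2 can only be bounded, not sized. Going by the values given here, the single measured step is an at least 2.6-fold higher number from compound 1 to compound 2 (0.42 log units; beyond the scatter), a worsening from the only compound with a numbered value.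

Compound 3 `Nc1nc(Cl)c2ncn(Cc3cccc(CCl)c3)c2n1` differs from compound 2 in one place: amino in place of chloro on an aromatic carbon. Among the compounds with values here, no measured pair exchanges chloro for amino at this carbon, so the step from compound 2 to compound 3 has no direct precedent. Within the data shown here, the one step that bears on it is the installation of this same chloro, which raised the number from compound 1 to compound 2; compound 3 removes that chloro again but puts amino in its place rather than hydrogen. The expected step of an at least 2.0-fold lower number from compound 2 to compound 3 (0.30 log units; that floor lies within the scatter) is accordingly taken as a modest move back toward the numbered region, with wide uncertainty and a real chance that the assay again reports only a limit. Compound 3 is estimated at 50000 nM, within 15000 nM to 150000 nM.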

Compound 3, concentration for total growth inhibition: > 100000 nM
Compound 3: no number, only a limit; the forecaster's own chance of this, stated with the estimate: 35%; middle value at least 2.0-fold (0.30 log units) away from the limit.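

In this assay compound 3 gives > 100000 nM, which is a limit of the assay and not a number. Amino on this aromatic carbon, between two ring nitrogen atoms, thus does not bring the series back to a numbered value, and against hydrogen at the same carbon the change is an at least 2.6-fold higher number from compound 1 to compound 3 (0.42 log units; beyond the scatter), so among the three groups shown here only hydrogen leaves a measurable value. The exchange of chloro for amino itself cannot be read, since both of its ends are limits, and the two groups cannot be ranked against each other: the limit of > 100000 nM in this assay, at which 2 of the 3 values shown sit.

As far as these compounds go, how far past the limit compound 2 and compound 3 lie stays open, so a real difference between chloro and amino at this carbon may exist without showing in these values. Also open, from the compounds shown here alone, is whether a smaller group such as fluoro or methyl, or a larger amine such as dimethylamino, on this carbon would keep a numbered value like that of compound 1 at 37200 nM.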